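A few compounds are considered here, and "the series" means these few. Any claim that something is new, unique, unknown or untested is made for them only; others in the source may bear on it.

Series notes. In an ADME assay on HPC cells (Homo sapiens) for cytotoxicity, with a stated time of 24 h (on this read-out lower numbers stand for higher toxicity in this test and higher numbers for lower toxicity in this test), compound 1 `O=C1/C(=C/c2ccccc2)CCC/C1=C\c1cccc([N+](=O)[O-])c1` gives 14000 nM. Compound 2 `O=C1/C(=C/c2ccc(F)cc2)CCC/C1=C\c1cccc([N+](=O)[O-])c1` carries fluoro in place of hydrogen on an aromatic carbon and in this assay gives 38000 nM, so the step is a 2.7-fold higher number from compound 1 to compound 2 (0.43 log units; beyond the scatter). Compound 3 `O=C1/C(=C/c2ccccc2)CCC/C1=C\c1ccc([N+](=O)[O-])cc1` rearranges the same atoms; the difference between the two cores is not broken down here, and in this assay compound 3 gives 123000 nM, the highest of the three numbers. Compound 4 `O=C1/C(=C/c2ccc(F)cc2)CCC/C1=C\c1ccc([N+](=O)[O-])cc1` is not yet measured; it differs from compound 3 by fluoro in place of hydrogen on an aromatic carbon, the same change as between compound 1 and compound 2, at the same kind of place. Among the compounds with values here, the step from compound 3 to compound 4 is expected to be a 2.1-fold higher number from compound 3 to compound 4 (0.33 log units; beyond the scatter), resting on the one earlier instance, compound 1 to compound 2 with a 2.7-fold higher number from compound 1 to compound 2 (0.43 log units; beyond the scatter). For compound 4 the estimate in this assay is 260000 nM, between 100000 nM and 650000 nM.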

Compound 4, half-maximal cytotoxic concentration: > 400000 nM
Compound 4 gave a limit, no number; the forecaster's own chance of this, stated with the estimate: 25%; at least 1.5-fold (0.18 log units) between middle value and limit.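

In this assay, fluoro in place of hydrogen on the other core again goes with a higher number, an at least 3.2-fold higher number from compound 3 to compound 4 (0.51 log units; beyond the scatter). Compound 4 gives > 400000 nM, which is a limit of the assay and not a number. The direction of the change therefore carries over across these two cores, but this does not show that the size of the step carries over: the same change on two cores in this assay, a 2.7-fold higher number (0.43 log units; beyond the scatter) from compound 1 to compound 2 and an at least 3.2-fold higher number (0.51 log units; beyond the scatter) from compound 3 to compound 4; the limit leaves it open whether they differ

The compounds shown leave open whether chloro, methoxy or an amine in place of fluoro on this ring would move the number in the same direction. They also leave open how fluoro would act on the ring carrying the nitro group.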